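Changing the aryl group on the hydrazone of a quinoline urea

The source may hold more compounds than are shown below. What is called first, only, known or untested is meant among the compounds shown, and "the series" means these compounds.

Measured compounds:
- compound 1, `COc1cc2c(Oc3ccc(NC(=O)N/N=C/c4ccc([N+](=O)[O-])cc4)cc3F)ccnc2cc1OCCCN1CCC(C)CC1`: 420 nM
- compound 2, `COc1cc2c(Oc3ccc(NC(=O)N/N=C/c4ccc(C(F)(F)F)cc4)cc3F)ccnc2cc1OCCCN1CCC(C)CC1`: 1000 nM

In a functional assay on MKN-45 cells (Homo sapiens) for cytotoxicity, read by MTT assay, with a stated time of 72 h (on this read-out lower numbers stand for stronger inhibition and higher numbers for weaker inhibition), compound 1 gives 420 nM and compound 2 gives 1000 nM. Compound 2 has the higher of the two numbers, with compound 1 the nearer one: the step was a 2.4-fold higher number from compound 1 to compound 2 (0.38 log units; beyond the scatter).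

Compound 3, `COc1cc2c(Oc3ccc(NC(=O)N/N=C/c4ccc(Cl)cc4Cl)cc3F)ccnc2cc1OCCCN1CCC(C)CC1`, is not yet measured. It differs from compound 2 in one place: 2,4-dichlorophenyl in place of 4-(trifluoromethyl)phenyl on a carbon with a double bond to nitrogen. Going by the values given here, only one measured step exists, the one from compound 1 to compound 2, and it swapped a single substituent on the same aryl ring, whereas the change to compound 3 replaces the whole ring. That step was modest but beyond the scatter, so a shift of similar size in either direction is plausible, and no direction can be read from the data. Compound 3 is expected to stay close to compound 2, with a 1.4-fold lower number from compound 2 to compound 3 (0.15 log units; within the scatter); the estimate for compound 3 is 700 nM, between 200 nM and 2500 nM.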

Compound 3, half-maximal inhibitory concentration: 350 nM
For compound 3 the middle estimate is 2.0-fold (0.30 log units) above the measured one; the range from low to high includes it.
By their numbers in this assay, from the lowest: compounds 3 and 1 (each within the scatter of the next); then compound 2.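

In this assay, replacing the whole aryl ring on this carbon with a double bond to nitrogen gives a 2.9-fold lower number from compound 2 to compound 3 (0.46 log units; beyond the scatter) as a modest step beyond the scatter, opposite in direction to the earlier swap of nitro for trifluoromethyl. The 2,4-dichlorophenyl and 4-nitrophenyl compounds cannot be told apart, with a 1.2-fold lower number from compound 1 to compound 3 (0.08 log units; within the scatter) inside the scatter, so among these three aryl groups only 4-(trifluoromethyl)phenyl stands apart, with the weaker number. Nothing measured here explains why these aryl groups rank this way. On these data alone, it remains open whether both chlorines matter, which a 4-chlorophenyl or 2-chlorophenyl group would test. How this position responds to a ring carrying an amine or a carboxylic acid, or to a pyridine ring in place of the benzene ring, is also unknown.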